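The compounds below may be only part of what the source reports. "The series", "measured", "known", "first", "only" and "open" are said of these compounds alone.

Compound 1 `CCCc1nn(C)c2c(NC3CC3)nc(/C=C/c3ccc[n+]([O-])c3)nc12` gives 580000 nM in a functional assay on L02 cells (Homo sapiens) for inhibition, read by Griess assay, with stated times of 1 h and 24 h; a lower number here means a stronger inhibitor, a higher number a weaker inhibitor.
Compound 2 `Brc1cccc(Nc2nc(/C=C/c3ccccc3)nc3ccsc23)c1` reaches only a limit of the assay, > 1000000 nM.
Compound 3 `CNc1nc(/C=C/c2cc(OC)c(OC)c(OC)c2)nc2ccsc12` likewise reaches only a limit, > 1000000 nM.

Compound 3 therefore stands at the limit of > 1000000 nM in this assay, at which 2 of the 3 values shown sit; it has no measured number of its own, only the edge of what this assay can report, and compound 2, which also carries an arylamine on the shared core, sits at the same edge. Only compound 1 gives a number, and that number is weak.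

Compound 4 `COc1cc(/C=C/c2nc(Nc3ccc(O)cc3)c3sccc3n2)cc(OC)c1OC` differs from compound 3 by 4-hydroxyphenyl in place of methyl on a nitrogen on an aromatic ring. Among the measured compounds shown here, no step between measured compounds on this core is known, so the size of this step cannot be read from a precedent; the nearest point of comparison is compound 2, whose arylamine on the shared core also gave only a limit.

Compound 4 is therefore expected to remain weak, with the step that the limit leaves unreadable from compound 3 to compound 4 expected to lie within the usual scatter. Compound 4 is estimated at 1500000 nM, ranging from 500000 nM to 5000000 nM, with a good chance that this assay again reports only a limit.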

Compound 4, half-maximal inhibitory concentration: > 1000000 nM
Compound 4: a limit, no number; the forecaster's own chance of this, stated with the estimate: 70%; the middle value is on the limit's open side.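

Compound 3 and compound 4 both give only a limit in this assay, so no step can be read between them: the limit of > 1000000 nM in this assay, at which 3 of the 4 values shown sit.

The compounds shown leave open whether 4-hydroxyphenyl in place of methyl on a nitrogen on an aromatic ring changes inhibition at all, and by how much.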